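The source may report more compounds than this note shows. Statements on the series, on what has been measured and on what is new or still open speak of the compounds shown alone.

Measured compounds:
Compound 1, `Fc1ccc(/C=N/NC(=S)Nc2nc3ccc(Cl)cc3s2)cc1`: 30 mg/kg
Compound 2, `CC(C)(C)NCC(=O)Nc1nc2ccc(Cl)cc2s1`: 100 mg/kg
Compound 3, `O=C(CNc1ccc(F)cc1)Nc1nc2ccc(Cl)cc2s1`: 100 mg/kg

All three share one core and were tested in a functional assay on the whole organism with Mus musculus as the target, in the maximal electroshock model, with a stated time of 4 h; a lower number here means that less compound is needed, a higher number that more compound is needed for the effect. Compound 1 gives the lowest of the three numbers; compound 2, the nearest to it, gives 100 mg/kg, and compound 3, the furthest, gives 100 mg/kg, both gaps being beyond the scatter. Within the data shown here, the only step among the measured compounds, no change at the digits printed from compound 2 to compound 3 (within the scatter), swaps the group on an amine nitrogen and leaves the number unchanged within the scatter.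

Compound 4, `S=C(N/N=C/c1ccccc1)Nc1nc2ccc(Cl)cc2s1`, has not yet been tested. It differs from compound 1 in one place: hydrogen in place of fluoro on an aromatic carbon. Among the measured compounds shown here, no measured step touches that position; the step from compound 2 to compound 3 changes a different part of the molecule and does not bear directly on the loss of a single fluoro. With nothing in the data speaking for a change, the expectation for compound 4 in this assay is a number close to that of compound 1, with the step of no change at the digits printed from compound 1 to compound 4 (within the scatter) expected to lie within the scatter. Compound 4 is therefore estimated at 30 mg/kg, within a range from 15 mg/kg to 100 mg/kg.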

Compound 4, minimum effective dose: 300 mg/kg
The estimate for compound 4 lay 10-fold (1.00 log units) below the measured number; measured number outside the range, above it.
By their numbers in this assay, from the lowest: compound 1; then compounds 2 and 3 (each within the scatter of the next); then compound 4.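

In this assay, the change from 4-fluorophenyl to phenyl gives a 10-fold higher number from compound 1 to compound 4 (1.00 log units; beyond the scatter) and so shows that this position, on an aromatic carbon para to a large group, is not indifferent to what it carries. Among these compounds, the earlier compounds could not show this: their only step, no change at the digits printed from compound 2 to compound 3 (within the scatter), concerns a group on an amine nitrogen and stays within the scatter, whereas here the loss of one fluoro, a single heavy atom, moves the number beyond the scatter. The data offer no measurement that bears on the reason for this step.

What the compounds shown leave open is whether the fluoro itself is needed at this position, or whether a methoxy or a nitrile group on the same carbon would keep the number near that of compound 1 rather than near that of compound 4. Going by these compounds, it also remains open whether the same change from 4-fluorophenyl to phenyl would have a comparable effect on compound 3, which carries its 4-fluorophenyl on an amine nitrogen rather than on the chain of compound 1.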